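The source may hold more compounds than are shown below. What is called first, only, known or untested is meant among the compounds shown, and "the series" means these compounds.

In a functional assay on PC-3 cells (Homo sapiens) (a lower number here means a stronger inhibitor of growth, a higher number a weaker inhibitor of growth), compound 3 `O=S(=O)(/C=C/c1ccc(Cl)c(Cl)c1)Cc1ccc(Nc2ncnc3ccc(Br)cc23)cc1` reads 11000 nM and compound 1 `O=S(=O)(/C=C/c1ccc(Cl)cc1Cl)Cc1ccc(Nc2ncnc3ccccc23)cc1` reads 19000 nM and these two values lie within the scatter of each other. Compound 2 `O=S(=O)(/C=C/c1ccc(F)cc1Cl)Cc1ccc(Nc2ncnc3ccccc23)cc1` reads 100000 nM and stands clearly higher than both, which puts compound 3 in the low pair of this small set. Compound 4 `O=S(=O)(/C=C/c1ccc(C(F)(F)F)cc1F)Cc1ccc(Nc2ncnc3ccc(Br)cc23)cc1` comes from compound 3 by one change. That change is 2-fluoro-4-(trifluoromethyl)phenyl in place of 3,4-dichlorophenyl on a double-bonded chain carbon bound to a double-bonded chain carbon and it places 2-fluoro-4-(trifluoromethyl)phenyl in place of 3,4-dichlorophenyl on a double-bonded chain carbon bound to a double-bonded chain carbon. Within the data shown here, one measured step bears on it, a 5.3-fold higher number from compound 1 to compound 2 (0.72 log units; beyond the scatter) with fluoro in place of chloro on an aromatic carbon, and on that step a rise of similar size is expected in this assay beyond the scatter. Among the measured compounds shown here, no measured step covers trifluoromethyl, so the range stays wide. The expected step is a 3.2-fold higher number from compound 3 to compound 4 (0.50 log units; beyond the scatter) on this estimate. For compound 4 the estimated value is 35000 nM with an expected range from 12000 nM to 100000 nM in this read-out.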

Compound 4, concentration for 50% growth inhibition: 58000 nM
Compound 4: the middle estimate sits 1.7-fold (0.22 log units) below what was measured; low and high end bracket the measured number.
By their numbers in this assay, from the lowest: compounds 3 and 1 (each within the scatter of the next); then compounds 4 and 2 (each within the scatter of the next).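

In this assay, 2-fluoro-4-(trifluoromethyl)phenyl in place of 3,4-dichlorophenyl on a double-bonded chain carbon bound to a double-bonded chain carbon gives a 5.3-fold higher number from compound 3 to compound 4 (0.72 log units; beyond the scatter) and thus a weaker inhibitor of growth. The earlier step, a 5.3-fold higher number from compound 1 to compound 2 (0.72 log units; beyond the scatter), covered only fluoro in place of chloro on an aromatic carbon, whereas this one shows a rise beyond the scatter for an exchange of the whole substituted phenyl group on the bromo-bearing core of compound 3. No measurement at hand explains the rise.

Fluoro and trifluoromethyl enter together here, so their separate shares in the step stay open. Also open, going by these compounds, is how this position would read with a methoxy, an amine or a carboxylic acid on the phenyl group.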